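Moving a hydroxyl across a ring: compound 2 to 3

The source may report more compounds than this note shows. Statements on the series, on what has been measured and on what is new or still open speak of the compounds shown alone.

Compound 1 `Oc1ccc(-c2cc(-c3ccc(F)cc3)cc(-c3ccc(O)cc3)n2)cc1` — 5260 nM
Compound 2 `Oc1ccc(-c2cc(-c3cccc(C(F)(F)F)c3)cc(-c3cccc(O)c3)n2)cc1` — 2630 nM

Going by the values given here, both compounds have been tested in a functional assay on T47D cells (Homo sapiens) for inhibition; a higher number here means a weaker inhibitor, a lower number a stronger inhibitor. Compound 2 gives 2630 nM, the lower of the two numbers, and compound 1 gives 5260 nM; the gap between them lies within the scatter, so the two cannot be ranked.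

Compound 3 `Oc1ccc(-c2cc(-c3cccc(C(F)(F)F)c3)cc(-c3ccc(O)cc3)n2)cc1` has not yet been measured. It shares the core of compound 2 and differs in one place: 4-hydroxyphenyl in place of 3-hydroxyphenyl on an aromatic carbon. The atoms are the same; only the point where the hydroxyl sits on that ring moves. Compound 1 already carries two 4-hydroxyphenyl groups and sits within the scatter of compound 2, so no step beyond the scatter is expected here; the estimated step from compound 2 to compound 3 is a 1.3-fold higher number from compound 2 to compound 3 (0.12 log units; within the scatter). Compound 3 is therefore expected to give about 3500 nM, between 1200 nM and 10000 nM.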

Compound 3, half-maximal inhibitory concentration: > 50000 nM
Compound 3: no number, only a limit; the forecaster's own chance of this, stated with the estimate: 5%; middle value at least 14-fold (1.15 log units) away from the limit.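

The value of compound 3 in this assay is a limit and not a number: the limit of > 50000 nM in this assay, at which 1 of the 3 values shown sits. With the atoms unchanged, 4-hydroxyphenyl in place of 3-hydroxyphenyl next to the ring nitrogen gives an at least 19-fold higher number from compound 2 to compound 3 (1.27 log units; beyond the scatter), so at this position the place of the hydroxyl on the ring counts for a great deal. Exchanging a different group, 3-(trifluoromethyl)phenyl in place of 4-fluorophenyl, gives an at least 9.5-fold higher number from compound 1 to compound 3 (0.97 log units; beyond the scatter), so two 4-hydroxyphenyl groups do not by themselves bring this loss, and the result depends on the group that accompanies them.

The compounds shown leave open whether moving the hydroxyl would matter as much in a compound carrying 4-fluorophenyl. They also leave open whether an amino or a methoxy group could take the place of that hydroxyl.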